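The source may report more compounds than this note shows. Statements on the series, on what has been measured and on what is new or still open speak of the compounds shown alone.

Compound 3 `CC(=O)N1CCC(Sc2c[nH]c3ccc(Br)cc23)CC1` is one of three compounds with a value in a functional assay on the whole organism with Mus musculus as the target, in the hot plate test; on this read-out higher numbers stand for an effect only at larger amounts of compound and lower numbers for an effect already at smaller amounts. Compound 1 `Clc1ccc2[nH]cc(SC3CCNCC3)c2c1` gives 1.2 mg/kg. Compound 2 `CC(=O)N1CCC(Sc2c[nH]c3ccc(Cl)cc23)CC1` gives 3.8 mg/kg, and the step of a 3.2-fold higher number from compound 1 to compound 2 (0.50 log units; beyond the scatter) comes from replacing the hydrogen on the ring amine nitrogen with an acetyl group. Compound 3 gives 2.8 mg/kg, reached by the step of a 1.4-fold lower number from compound 2 to compound 3 (0.13 log units; within the scatter). On these numbers compound 3 stands second highest of the three, closest to compound 2 and furthest from compound 1.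

Compound 4 `CCOC(=O)N1CCC(Sc2c[nH]c3ccc(Br)cc23)CC1` differs from compound 3 in one place: ethoxy in place of methyl on a carbonyl carbon. The carbonyl group on the ring nitrogen stays, and only the group on its carbonyl carbon is exchanged. For the measured compounds named here, no measured pair varies this position. Going by the values given here, the only step that touches the same part of the molecule is a 3.2-fold higher number from compound 1 to compound 2 (0.50 log units; beyond the scatter), which introduced the acetyl group and was modest in size. The swap of bromo for chloro, a 1.4-fold lower number from compound 2 to compound 3 (0.13 log units; within the scatter), sits on the aromatic ring far from the change and offers little guidance.

Given that the carbonyl remains and only the group attached to it grows, the expected step is small, likely a 1.3-fold higher number from compound 3 to compound 4 (0.10 log units; within the scatter), with no clear direction beyond the scatter. The estimate for compound 4 in this assay is therefore 3.5 mg/kg, within a range from 1.8 mg/kg to 7 mg/kg.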

Compound 4, dose for half-maximal effect: 27.3 mg/kg
For compound 4 the middle estimate is 7.8-fold (0.89 log units) below the measured one; the measured number lies above the stated range.
By their numbers in this assay, from the lowest: compound 1; then compounds 3 and 2 (each within the scatter of the next); then compound 4.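

Keeping the carbonyl on the ring nitrogen does not make this position forgiving: exchanging methyl for ethoxy on the carbonyl carbon, which turns acetyl into ethoxycarbonyl, gives a 9.8-fold higher number from compound 3 to compound 4 (0.99 log units; beyond the scatter) in this assay and means that far more compound is needed for the same effect. For the compounds shown here, the only earlier change at this end of the molecule, a 3.2-fold higher number from compound 1 to compound 2 (0.50 log units; beyond the scatter), replaced hydrogen with acetyl, and it could not show whether the group on the carbonyl carbon matters once the carbonyl is in place. Compound 4 shows that it does, by a larger step than the earlier one, but no measurement here explains this.

Ethoxy brings in an oxygen and also more carbon at once, and the compounds shown do not tell which of these goes with the step. An ethyl group on the carbonyl carbon would keep the added carbon without the oxygen, while a methoxy group would keep the oxygen with less carbon, and either result would help separate the two.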